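The source may hold more compounds than are shown below. What is called first, only, known or untested is meant among the compounds shown, and "the series" means these compounds.

Working notes on the series. Among the compounds with values here, in an assay on HEK293 cells for inhibition of acid ceramidase (Homo sapiens), with a stated time of 10 min (on this read-out higher numbers stand for weaker inhibition and lower numbers for stronger inhibition), compound 2 `O=C(NCCCCc1ccccc1)n1c(=O)oc2cc(Br)ccc21` gives 31 nM, the lowest of the two numbers so far; compound 1 `O=C(NCCCCc1ccccc1)n1c(=O)oc2cc(-c3ccc(F)cc3)ccc21` gives 79 nM in this assay, and the step of a 2.5-fold lower number from compound 1 to compound 2 (0.41 log units; beyond the scatter) is the only measured one. Compound 3 `Cc1ccc2c(c1)oc(=O)n2C(=O)NCCCCc1ccccc1` has not yet been measured. Its change from compound 2 is methyl in place of bromo on an aromatic carbon. Within the data shown here, no measured step covers a bromo-to-methyl exchange at this position; the one step in hand concerns a different exchange at the same place and was modest in size, so it bears only loosely on the question. With nothing pointing to a large effect, the step from compound 2 to compound 3 is expected to be small, probably upward and near the edge of the scatter, as a 1.9-fold higher number from compound 2 to compound 3 (0.29 log units; within the scatter). Compound 3 is therefore estimated at 60 nM in this assay, with a range of 20 nM to 180 nM.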

Compound 3, half-maximal inhibitory concentration: 66 nM
Compound 3: the middle estimate sits 1.1-fold (0.04 log units) below what was measured, within the range that was stated.
By their numbers in this assay, from the lowest: compound 2; then compounds 3 and 1 (each within the scatter of the next).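

In this assay, methyl in place of bromo gives a 2.1-fold higher number from compound 2 to compound 3 (0.33 log units; beyond the scatter), so this position distinguishes two groups of one heavy atom each, and compound 2 stands as the strongest of the three, with its steps to both others printed beyond the scatter. Methyl and 4-fluorophenyl, by contrast, are not separated here, with a 1.2-fold lower number from compound 1 to compound 3 (0.08 log units; within the scatter), so a group that adds a whole ring at this aromatic carbon and one that adds no ring read alike. No supporting measurement accompanies these numbers to account for the edge held by bromo.

The compounds shown leave open whether that edge is particular to bromo or would be shared by chloro, methoxy or an amine at this position. They also leave open whether the same order of bromo, methyl and 4-fluorophenyl would hold with a shorter chain in place of the phenyl-bearing chain.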